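The source may hold more compounds than are shown below. What is called first, only, known or untested is meant among the compounds shown, and "the series" means these compounds.

Compound 1 `Cc1c(OCCCCOc2ccc(C(=O)O)cc2F)ccc(C(=O)CC(C)C)c1O` gives 67.7% in an assay on HEK293 cells for positive allosteric modulation of metabotropic glutamate receptor 3 (Rattus norvegicus), read by thallium flux, with a stated time of 2.5 min; on this read-out lower numbers stand for smaller maximal responses and higher numbers for larger maximal responses.
Compound 2 `Cc1c(OCCCCOc2ccc(C(=O)O)cc2)ccc(C(=O)CC(C)C)c1O` gives 51.9%.
Compound 3 `Cc1c(OCCCCOc2cccc(C(=O)O)c2)ccc(C(=O)CC(C)C)c1O` gives 69.9%.

Compound 3 has the highest number of the three, but it sits within the scatter of compound 1, so these two cannot be ranked; only compound 2 stands clearly lower. Compound 4 `Cc1c(OCCCCOc2ccccc2C(=O)O)ccc(C(=O)CC(C)C)c1O` has not yet been measured. It differs from compound 3 by 2-carboxyphenyl in place of 3-carboxyphenyl on an oxygen on a saturated carbon. Among the measured compounds shown here, the one measured step that bears on this is the earlier exchange of one carboxyphenyl for another, a number 18 percentage points higher from compound 2 to compound 3 (beyond the scatter), a modest change. A further exchange of this kind is therefore expected to shift the maximal response by a modest amount, while the data give no sign of its direction. Compound 4 is estimated at 60%, between 42% and 78%, which is expected to mean a number 9.9 percentage points lower from compound 3 to compound 4 (within the scatter).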

Compound 4, largest response reached (reported as percent of maximum), in percent of the reference or control that the assay uses: 28.1%
Compound 4: the middle estimate sits 31.9 percentage points above what was measured; measured number below the stated range.
By their numbers in this assay, from the lowest: compound 4; then compound 2; then compounds 1 and 3 (each within the scatter of the next).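

Placing the acid as 2-carboxyphenyl shows that the maximal response at this position depends strongly on where the carboxylic acid sits on the ring: in this assay, the exchange gives a number 41.8 percentage points lower from compound 3 to compound 4 (beyond the scatter) and a number 23.8 percentage points lower from compound 2 to compound 4 (beyond the scatter). The fluorinated group fares no better as a starting point, with a number 39.6 percentage points lower from compound 1 to compound 4 (beyond the scatter). Nothing measured here explains this sensitivity.

On these data alone, it remains open whether an amide or a tetrazole could replace the carboxylic acid on the ring. A longer chain between the two oxygens is also untested territory for the 3-carboxyphenyl group.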